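Aryl exchange on the shared core of the series

The compounds below may be only part of what the source reports. "The series", "measured", "known", "first", "only" and "open" are said of these compounds alone.

Compound 1 `Cc1ccccc1-n1nncc1CN1C(=O)C2(C(C#N)=C(N)Oc3c2c2nc4ccccc4nc2c2ccccc32)c2ccccc21` sits at the limit in an ADME assay on L02 cells (Homo sapiens) for antiproliferative activity, read by MTT assay, with a stated time of 48 h (on this read-out higher numbers stand for weaker inhibition and lower numbers for stronger inhibition), with > 50000 nM. Compound 2 `COc1ccccc1-n1nncc1CN1C(=O)C2(C(C#N)=C(N)Oc3c2c2nc4ccccc4nc2c2ccccc32)c2ccccc21` likewise gives only a limit, > 50000 nM. The step that the two limits leave unreadable from compound 1 to compound 2 therefore cannot be read, and both values fall on the same line, (the limit of > 50000 nM in this assay, at which 2 of the 2 values shown sit). Compound 3 `N#CC1=C(N)Oc2c(c3nc4ccccc4nc3c3ccccc23)C12C(=O)N(Cc1cnnn1-c1ccc(Cl)c(Cl)c1)c1ccccc12` carries 3,4-dichlorophenyl in place of 2-methoxyphenyl on an aromatic nitrogen. Among the compounds with values here, no measured step bears on this change, so for this assay no readable step is available as a guide. Compound 3 is expected to remain at the limit, with the step of a number no higher from compound 2 to compound 3 (the limit leaves the size open) taken as none beyond the scatter. The estimate for compound 3 is 50000 nM, with a range from 20000 nM to 100000 nM.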

Compound 3, half-maximal inhibitory concentration: > 50000 nM
Compound 3: no number, only a limit; the forecaster's own chance of this, stated with the estimate: 75%; the middle value lies on the limit itself.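

Within the data shown here, compound 3 gives only a limit, as do compound 1 and compound 2, so no new step among them can be read: the limit of > 50000 nM in this assay, at which 3 of the 3 values shown sit. On these data alone, whether any aryl group on the shared core gives a readable value in this assay remains open.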